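Bromo-to-nitro exchange on the phenyl of bis-indolyl methanes

A few compounds are considered here, and "the series" means these few. Any claim that something is new, unique, unknown or untested is made for them only; others in the source may bear on it.

Compound 1 `Brc1ccc(C(c2c[nH]c3ccc(Br)cc23)c2c[nH]c3ccc(Br)cc23)cc1` and compound 2 `O=[N+]([O-])c1ccc(C(c2c[nH]c3ccc(Br)cc23)c2c[nH]c3ccc(Br)cc23)cc1` share a core in which the two indole rings carry bromo groups; compound 3 `O=[N+]([O-])c1ccc2[nH]cc(C(c3ccc(Br)cc3)c3c[nH]c4ccc([N+](=O)[O-])cc34)c2c1` carries nitro groups on both indoles instead, and compound 4 `O=[N+]([O-])c1ccc(C(c2c[nH]c3ccc([N+](=O)[O-])cc23)c2c[nH]c3ccc([N+](=O)[O-])cc23)cc1` keeps that core with a nitro group on the phenyl as well. In a functional assay on MCF7 cells (Homo sapiens) for inhibition, read by MTT assay, with a stated time of 48 h (on this read-out higher numbers stand for weaker inhibition and lower numbers for stronger inhibition), compound 1 gives 3200 nM. In this assay compound 2 gives 3100 nM. The change nitro in place of bromo on an aromatic carbon made a step of a 1.0-fold lower number from compound 1 to compound 2 (0.01 log units; within the scatter). For compound 3 this assay reports only a limit, > 100000 nM; see (the limit of > 100000 nM in this assay, at which 1 of the 3 values shown sits). How the core of compound 3 differs from that of compound 1 is not broken down here. The change from compound 3 to compound 4 is the same, (nitro in place of bromo on an aromatic carbon), at the same place. Given that the step from compound 1 to compound 2 stayed within the scatter, compound 4 is expected to remain near the limit seen for compound 3, with a step that the limit leaves unreadable from compound 3 to compound 4. The estimate for compound 4 is 120000 nM, between 30000 nM and 400000 nM.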

Compound 4, half-maximal inhibitory concentration: 22500 nM
For compound 4 the middle estimate is 5.3-fold (0.73 log units) above the measured one; measured number below the stated range.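

In this assay the change from 4-bromophenyl to 4-nitrophenyl gives a 1.0-fold lower number from compound 1 to compound 2 (0.01 log units; within the scatter) on the core with bromo groups on the indoles, and an at least 4.4-fold lower number from compound 3 to compound 4 (0.64 log units; beyond the scatter) on the core with nitro groups on the indoles. In this series the change therefore does not carry over with the same size from one core to the other: the same change on two cores in this assay, a 1.0-fold lower number (0.01 log units; within the scatter) from compound 1 to compound 2 and an at least 4.4-fold lower number (0.64 log units; beyond the scatter) from compound 3 to compound 4, at least 4.3-fold (0.63 log units) apart, beyond the scatter of two such steps The value of compound 3, > 100000 nM, is a limit and not a number, so the second step has only a lower bound and its full size stays unread; the two cores show that the outcome depends on the core in this pair, but they give no reason for it and no rule for other cores.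

What the compounds shown leave open is how an amine or a carboxylic acid in place of the bromo group on the phenyl would read on either core. Also open, going by these compounds, is how a core with one bromo group and one nitro group on its indoles would respond to the same change.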